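The source may report more compounds than this note shows. Statements on the series, on what has been measured and on what is new or still open speak of the compounds shown alone.

Compound 1 `N#Cc1ccc(Nc2nc(NC3CCCC3)c3ccccc3n2)cc1`: > 31300 nM
Compound 2 `Nc1ccc(Nc2nc(NC3CCCC3)c3ccccc3n2)cc1`: 18700 nM

Both compounds were tested in a functional assay on DU-145 cells (Homo sapiens) for antiproliferative activity, read by sulforhodamine B assay, with a stated time of 48 h; on this read-out lower numbers stand for stronger inhibition of growth and higher numbers for weaker inhibition of growth. For the measured compounds named here, compound 2, at 18700 nM, holds the only actual number in this small series. For compound 1, > 31300 nM is a limit of the assay and not a number.

Compound 3 `O=C(O)c1ccc(Nc2nc(NC3CCCC3)c3ccccc3n2)cc1` keeps the shared core of compound 2 and has carboxy in place of amino on an aromatic carbon, para to a large group: carboxy in place of amino on an aromatic carbon. Going by the values given here, one measured step bears on this change, at the same aromatic carbon: an at least 1.6-fold lower number from compound 1 to compound 2 (0.22 log units; that floor lies within the scatter). Among the compounds with values here, that step gives only a floor for its size, and no measured compound carries the carboxy group, so the evidence is thin. Within the data shown here, compound 1 is the only measured compound that lacks the amino group, and it lies on the side of weaker inhibition in this assay, so a small move in that direction is expected. The expected step is a 1.6-fold higher number from compound 2 to compound 3 (0.21 log units; within the scatter). Compound 3 is estimated at 30000 nM, with an expected range from 12000 nM to 70000 nM.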

Compound 3, concentration for 50% growth inhibition: 27300 nM
The estimate for compound 3 lay 1.1-fold (0.04 log units) above the measured number; low and high end bracket the measured number.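

In this assay, the aromatic carbon para to a large group now carries two actual numbers, and carboxy in place of amino gives a 1.5-fold higher number from compound 2 to compound 3 (0.16 log units; within the scatter), so these two groups cannot be told apart at this position, although one is a single heavy atom and the other has 3 heavy atoms. Carboxy in place of cyano gives an at least 1.1-fold lower number from compound 1 to compound 3 (0.05 log units; that floor lies within the scatter), so this pair shows no separation that can be read either. Compound 1 holds a limit and not a number, and this is why its step can only be stated as a floor: the limit of > 31300 nM in this assay, at which 1 of the 3 values shown sits.

What the compounds shown leave open is whether any group at this carbon, such as a hydroxyl, a methoxy or an amide, would move the number beyond the scatter. As far as these compounds go, it is also open whether the cyano group truly differs from amino or carboxy, and whether a change elsewhere on the shared core, such as a longer chain in place of the cyclopentyl amine, would matter more than the change at this position.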